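Phenyl in place of chloro on a shared core

This account rests on a few compounds, and the source may have more. Where it says the series, first, only, none or still open, it means among the compounds named here.

Compound 3 `CC(=O)c1ccc(Nc2ccnc(SCC(=O)c3ccc(Cl)cc3)n2)cc1` gives 13% in a functional assay on NCI-H23 cells (Homo sapiens) for inhibition, read by sulforhodamine B assay, with a stated time of 48 h, tested at 10 uM (a lower number here means less inhibition of growth, a higher number more inhibition of growth at the concentration tested), the lowest of three numbers, though within the scatter of both others. For the measured compounds named here, compound 1 `CC(=O)c1ccc(Nc2ccnc(SCC(=O)c3ccc(Br)cc3)n2)cc1` gives 16%, and the only single-point step so far, a number 3 percentage points lower from compound 1 to compound 3 (within the scatter), stays within the scatter. Compound 2 `CC(=O)c1cccc(Nc2ccnc(SCC(=O)c3ccc(-c4ccccc4)cc3)n2)c1`, which carries a phenyl group on a slightly different core, gives 18%. Compound 4 `CC(=O)c1ccc(Nc2ccnc(SCC(=O)c3ccc(-c4ccccc4)cc3)n2)cc1` differs from compound 3 by phenyl in place of chloro on an aromatic carbon. Going by the values given here, no measured step covers this exact exchange; the halogen swap was flat, and compound 2 with its phenyl sits close to the others, so no step beyond the scatter is expected: a number 4 percentage points higher from compound 3 to compound 4 (within the scatter). Compound 4 is estimated at 17%, between 8% and 28%.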

Compound 4, percent growth inhibition at one concentration: 10%
Compound 4: middle estimate off by 7 percentage points, on the high side; low and high end bracket the measured number.
By their numbers in this assay, from the lowest: compounds 4, 3, 1 and 2 (each within the scatter of the next).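

In this assay, putting phenyl in place of a single halogen atom on this aromatic carbon gives a number 3 percentage points lower from compound 3 to compound 4 (within the scatter) and, against the bromo compound, a number 6 percentage points lower from compound 1 to compound 4 (within the scatter). Six heavy atoms entering here for one leaving therefore produce no step beyond the scatter. Shifting the acetyl group, with 4-acetylphenyl in place of 3-acetylphenyl on the nitrogen, gives a number 8 percentage points lower from compound 2 to compound 4 (within the scatter), and nothing available explains why these numbers stay so close. Going by these compounds, whether an amine or a carboxylic acid at this position would move the number remains open.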